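Indole and indazole acrylamides against CDK8: methylamide to morpholine amide

A few compounds are considered here, and "the series" means these few. Any claim that something is new, unique, unknown or untested is made for them only; others in the source may bear on it.

Measured compounds:
compound 1 `CNC(=O)/C=C/c1ccncc1-c1ccc2cc[nH]c2c1`, 18.6 nM
compound 2 `Cn1ncc2cc(-c3cnccc3/C=C/C(=O)N3CCOCC3)ccc21`, 356 nM
compound 3 `CN1CCN(c2ccc(Nc3cnccc3/C=C/C(N)=O)cc2)CC1`, "not determined" (no result reported)

In an assay on a protein complex for inhibition of CDK8/Cyclin C (Homo sapiens), with a stated time of 1 h (a lower number here means a stronger inhibitor, a higher number a weaker inhibitor), compound 1 gives 18.6 nM, the lowest of the two numbers in hand. Compound 2, which carries both a different amide and a different bicycle, gives 356 nM in this assay, a higher number and beyond the scatter. Two parts differ between compound 1 and compound 2 at once. Among the measured compounds shown here, the two values show only that compound 2 is the weaker of the pair, not which part accounts for it. Compound 3 is given as "not determined" (no result reported) in this assay.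

Compound 4 `O=C(/C=C/c1ccncc1-c1ccc2cc[nH]c2c1)N1CCOCC1` is the next step from compound 1: morpholin-4-yl in place of methylamino on a carbonyl carbon. No single change of this kind has been measured here. For the measured compounds named here, the morpholine amide is otherwise seen only in compound 2, whose value 356 nM in this assay sits well above that of compound 1, so a move toward a higher number is expected, of moderate size, while the shared indole of compound 1 should keep compound 4 from reaching the level of compound 2.

For compound 4 the step of a 5.9-fold higher number from compound 1 to compound 4 (0.77 log units; beyond the scatter) is expected in this assay. Compound 4 is estimated at 110 nM in this assay, with a range from 35 nM to 350 nM.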

Compound 4, half-maximal inhibitory concentration: 43.9 nM
Compound 4: middle estimate off by 2.5-fold (0.40 log units), on the high side; the measured number falls inside the stated range.
By their numbers in this assay, from the lowest: compound 1; then compound 4; then compound 2.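

Morpholin-4-yl in place of methylamino on a carbonyl carbon gives a 2.4-fold higher number from compound 1 to compound 4 (0.37 log units; beyond the scatter) in this assay. Among the compounds shown here, this is the first reading of a change at this position alone, with the core of compound 1 held constant, and the step is modest: the change removes the amide hydrogen and adds a six-membered ring, yet compound 4 still gives 43.9 nM. No measurement in hand bears on the cause of this step.

From the compounds shown here alone, the loss of the amide hydrogen and the gain of the ring come together here, so their separate contributions remain open. A dimethylamino group on the same carbonyl carbon would remove that hydrogen without adding a ring, and a piperidin-1-yl group would keep a six-membered ring without the morpholine oxygen.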